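From Methoxy to Hydroxy at the Assay Limit

The source may hold more compounds than are shown below. What is called first, only, known or untested is meant among the compounds shown, and "the series" means these compounds.

Of the compounds shown here, three have been tested in an ADME assay on MCF7 cells (Homo sapiens) for cytotoxicity, with a stated time of 72 h; on this read-out lower numbers stand for stronger inhibition and higher numbers for weaker inhibition. Compound 1 `COc1cc(CNc2ncnc3c2ncn3C2CCCCO2)ccc1O` gives > 100000 nM, which is a limit and not a number. Compound 2 `COc1cccc(CNc2ncnc3c2ncn3C2CCCO2)c1` gives > 100000 nM, again a limit. Compound 3 `COc1ccc(CNc2ncnc3c2ncn3C2CCCO2)cc1OC` gives > 100000 nM, also a limit, so it has no exact number of its own.

Compound 4 `COc1cc(CNc2ncnc3c2ncn3C2CCCO2)ccc1O` has not yet been measured. Its difference from compound 3 is hydrogen in place of methyl on an oxygen on an aromatic ring, which turns a methoxy into a hydroxy. For the measured compounds named here, the one measured step that bears on this is a step that the two limits leave unreadable from compound 2 to compound 3, methoxy in place of hydrogen on an aromatic carbon. It gives no size to carry over. Going by the values given here, the only other guide is the limit of > 100000 nM in this assay, at which 3 of the 3 values shown sit. With no sign of a change in either direction, a shift beyond the usual scatter is not expected. The expected result is a step that the limit leaves unreadable from compound 3 to compound 4. Compound 4 is estimated at 120000 nM, with an expected range from 50000 nM to 300000 nM.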

Compound 4, half-maximal inhibitory concentration: > 100000 nM
Compound 4: a limit, no number; the forecaster's own chance of this, stated with the estimate: 85%; the middle value does not contradict the limit.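

For the compounds shown here, compound 1, compound 2, compound 3 and compound 4 each give only a limit in this assay, and no step between them can be read. The compounds shown leave open whether the methoxy to hydroxy change, or any other change among them, alters this read-out at all.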